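This account rests on a few compounds, and the source may have more. Where it says the series, first, only, none or still open, it means among the compounds named here.

In an ADME assay on HEK-293T cells (Homo sapiens) for cytotoxicity, read by luminescence, with a stated time of 24 h (a lower number here means that less compound is tolerated, a higher number that more compound is tolerated), compound 1 `CCOC(=O)c1cc2sccc2n1Cc1ccc(OC)cc1` gives > 100000 nM, which is a limit of the assay and not a number. Compound 2 `CCCNC(=O)C1CCN(C(=O)c2cc3sc(C(=O)c4ccccc4)cc3n2Cc2ccc(OC)cc2)CC1` gives > 100000 nM, and this is also a limit. Compound 2 therefore has no exact number of its own and stands with compound 1 at the limit of > 100000 nM in this assay, at which 2 of the 2 values shown sit. Compound 3 `CCCNC(=O)C1CCN(C(=O)c2cc3sc(C)cc3n2Cc2ccc(OC)cc2)CC1` differs from compound 2 in one place, on an aromatic carbon of a five-membered aromatic ring with 1 sulfur, next to the ring sulfur, where methyl replaces benzoyl: methyl in place of benzoyl on an aromatic carbon. Going by the values given here, no measured pair shows what such a change does in this assay. The expected step of a number no higher from compound 2 to compound 3 (the limit leaves the size open) is none beyond the usual scatter, with no direction favoured. The assay may well report only a limit again. Compound 3 is estimated at 100000 nM, with an expected range of 40000 nM to 200000 nM.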

Compound 3, half-maximal cytotoxic concentration: 36300 nM
Beside the measured number, compound 3's estimate is 2.8-fold (0.44 log units) above it, and the stated range ends above it.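

In this assay, methyl in place of benzoyl on an aromatic carbon, next to the ring sulfur, comes with an at least 2.7-fold lower number from compound 2 to compound 3 (0.44 log units; beyond the scatter). Going by these compounds alone, the earlier compounds showed only limits, so this is the first sign that the group at this carbon matters here: with methyl, the cells tolerate less compound than with benzoyl. Compound 2 gives a limit of the assay and not a number, so the full size of the step stays open: the limit of > 100000 nM in this assay, at which 2 of the 3 values shown sit.

This single pair cannot separate the loss of the benzoyl's aromatic ring from the loss of its carbonyl. Also open, from the compounds shown here alone, is whether a plain phenyl, an acetyl group or a longer chain such as propyl at this carbon would behave like the benzoyl of compound 2 or the methyl of compound 3.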